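Core swap on the amide of compound 1

The source may report more compounds than this note shows. Statements on the series, on what has been measured and on what is new or still open speak of the compounds shown alone.

Working notes on the series. Among the measured compounds shown here, in an ADME assay on microsomes from liver (Mus musculus) for metabolic stability, read by LC-MS, with a stated time of 30 min, tested at 1 uM (on this read-out higher numbers stand for a more stable compound and lower numbers for a less stable compound), compound 1 `O=C(NCc1ccc(S(=O)(=O)c2cc(F)cc(F)c2)cc1)c1cc2cnccc2[nH]1` gives 63%, the highest of the three numbers so far. Compound 2 `O=C(NCc1ccc(S(=O)(=O)c2ccccc2C(F)(F)F)cc1)c1cc2cnccc2[nH]1` gives 41% and compound 3 `O=C(NCc1ccc(S(=O)(=O)c2cccc(C(F)(F)F)c2)cc1)c1cc2cnccc2[nH]1` gives 49%; the steps of a number 22 percentage points lower from compound 1 to compound 2 (beyond the scatter) and a number 14 percentage points lower from compound 1 to compound 3 (beyond the scatter) both lie beyond the scatter, while a number 8 percentage points higher from compound 2 to compound 3 (within the scatter) does not. Compound 4 `O=C(NCc1ccc(S(=O)(=O)c2cc(F)cc(F)c2)cc1)c1cnc2nccn2c1` keeps the 3,5-difluorophenyl on the sulfonyl sulfur of compound 1 and changes the group on the carbonyl carbon instead: a group of 9 heavy atoms (6 carbon, 3 nitrogen; one five-membered aromatic ring with 2 hetero atoms, one six-membered aromatic ring with 2 hetero atoms) in place of a group of 9 heavy atoms (7 carbon, 2 nitrogen; one five-membered aromatic ring with 1 hetero atom, one six-membered aromatic ring with 1 hetero atom), on a carbonyl carbon. For the measured compounds named here, none of the measured steps touches this position; all three vary the aryl on the sulfonyl sulfur. No direction can be read from them, so a step of any size, or none beyond the scatter, is possible. Compound 4 is estimated at 55% (range 25% to 85%). The expected step is a number 8 percentage points lower from compound 1 to compound 4 (within the scatter).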

Compound 4, percent of the compound remaining: 71%
The estimate for compound 4 lay 16 percentage points below the measured number; the range from low to high includes it.
By their numbers in this assay, from the lowest: compounds 2 and 3 (each within the scatter of the next); then compounds 1 and 4 (each within the scatter of the next).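

In this assay, the position on the carbonyl carbon tolerates this exchange of bicyclic groups on the core of compound 1, with the step (a number 8 percentage points higher from compound 1 to compound 4 (within the scatter)) staying within the scatter. The entering group has 0 hydrogen-bond donors and 3 hydrogen-bond acceptors, against 1 of each in the group it replaces, so these changes come without a step beyond the scatter in this pair. No measurement at hand explains this result.

Still open, going by these compounds, is whether the same exchange holds with 3-(trifluoromethyl)phenyl on the sulfonyl sulfur. Also open, on these data alone, is what a plain phenyl or a morpholine group would give on this carbonyl carbon.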